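The compounds below may be only part of what the source reports. "The series", "measured", "known", "first", "only" and "open" are said of these compounds alone.

Going by the values given here, compound 2 `COc1ccc(/C=C\C(=O)O)c(OCc2cn(-c3ccc(CO)cc3)nn2)c1CC=C(C)C` gives 27100 nM in a functional assay on NCI-H322 cells (Homo sapiens) for cytotoxicity, read by MTT assay, with a stated time of 24 h (a higher number here means a weaker inhibitor, a lower number a stronger inhibitor), numerically the higher of the two figures recorded, though the gap to its only neighbour is within the scatter. Among the compounds with values here, that neighbour, compound 1 `COc1ccc(/C=C\C(=O)O)c(OCc2cn(-c3ccc(NC(=O)c4ccccc4)cc3)nn2)c1CC=C(C)C`, gives 17200 nM in this assay, and the step of a 1.6-fold higher number from compound 1 to compound 2 (0.20 log units; within the scatter) is the single measured change at this position. Compound 3 `COc1ccc(/C=C\C(=O)O)c(OCc2cn(-c3ccccc3C#N)nn2)c1CC=C(C)C` differs from compound 2 by 2-cyanophenyl in place of 4-(hydroxymethyl)phenyl on an aromatic nitrogen. Within the data shown here, since the one comparable swap on the group attached to the aromatic nitrogen barely moved the number, compound 3 is expected to give about 22000 nM in this assay, within 8000 nM to 60000 nM, a step of a 1.2-fold lower number from compound 2 to compound 3 (0.09 log units; within the scatter).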

Compound 3, half-maximal inhibitory concentration: 14400 nM
The estimate for compound 3 lay 1.5-fold (0.18 log units) above the measured number; the measured number falls inside the stated range.
By their numbers in this assay, from the lowest: compounds 3, 1 and 2 (each within the scatter of the next).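

In this assay, the change at the aromatic nitrogen from 4-(hydroxymethyl)phenyl to 2-cyanophenyl gives a step (a 1.9-fold lower number from compound 2 to compound 3 (0.27 log units; within the scatter)) that stays within the scatter. The position thus accepts a nitrile-bearing group with no hydrogen-bond donor, and a substituent placed differently on the phenyl ring, without a step beyond the scatter. No other measurement here bears on the reason for this result. The compounds shown leave open whether an amine or a carboxylic acid on the phenyl ring, or a longer chain replacing it, would move the number beyond the scatter.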